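Trifluoromethyl for Methylsulfonyl on a Shared Amide Core

A few compounds are considered here, and "the series" means these few. Any claim that something is new, unique, unknown or untested is made for them only; others in the source may bear on it.

Compound 1 `CS(=O)(=O)c1ccc(C(=O)Nc2ccc(Cl)c(-c3nnc4c(Cl)cccn34)c2)c(Cl)c1` — > 100000 nM
Compound 2 `O=C(Nc1ccc(Cl)c(-c2nnc3c(Cl)cccn23)c1)c1ccccc1` — > 100000 nM
Compound 3 `Cc1nc(C(=O)Nc2ccc(Cl)c(-c3nnc4c(Cl)cccn34)c2)cs1` — > 100000 nM

In a functional assay on T47D cells (Homo sapiens) for antiproliferative activity, read by MTT assay, with a stated time of 72 h (on this read-out lower numbers stand for stronger inhibition and higher numbers for weaker inhibition), compound 1 gives > 100000 nM, which is a limit of the assay and not a number. Compound 2 likewise stands at a limit, > 100000 nM. Compound 3 also gives only a limit, > 100000 nM. Within the data shown here, the one single-point step, a step that the two limits leave unreadable from compound 2 to compound 3, is therefore unreadable, as the limit of > 100000 nM in this assay, at which 3 of the 3 values shown sit, shows. Compound 4 `O=C(Nc1ccc(Cl)c(-c2nnc3c(Cl)cccn23)c1)c1ccc(C(F)(F)F)cc1Cl` differs from compound 1 by trifluoromethyl in place of methylsulfonyl on an aromatic carbon. Among the measured compounds shown here, no measured step bears on this change, and the three limits of the limit of > 100000 nM in this assay, at which 3 of the 3 values shown sit, give no readable potency anywhere in the set. A step that the limit leaves unreadable from compound 1 to compound 4 is expected, that is, none that can be read. Compound 4 is thus estimated at 150000 nM, between 30000 nM and 800000 nM, most probably reported again as a limit.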

Compound 4, half-maximal inhibitory concentration: > 100000 nM
Compound 4 ended at the assay's limit; the forecaster's own chance of this, stated with the estimate: 80%; the middle value is on the limit's open side.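

No step can be read between compound 1 and compound 4, because both give a limit and not a number: the limit of > 100000 nM in this assay, at which 4 of the 4 values shown sit.

The compounds shown leave open what trifluoromethyl in place of methylsulfonyl does to potency in this assay, and whether any compound on the shared core reaches a readable value there.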